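A few compounds are considered here, and "the series" means these few. Any claim that something is new, unique, unknown or untested is made for them only; others in the source may bear on it.

Series notes, measured in a physicochemical assay, read by spectrophotometry, with a stated time of 20 min; a lower number here means a stronger inhibitor, a higher number a weaker inhibitor:

- compound 1 `CC(C)(C)c1ccc(-c2oc3cc(O)cc(O)c3c(=O)c2O)cc1`: 709000 nM
- compound 2 `CN(C)c1ccc(-c2oc3cc(O)cc(O)c3c(=O)c2O)cc1`: 612000 nM

For the measured compounds named here, compound 2, at 612000 nM, stands within the scatter of compound 1, the only other measured compound, so the two numbers cannot be ranked. Going by the values given here, the single measured step is a 1.2-fold lower number from compound 1 to compound 2 (0.06 log units; within the scatter). It exchanges tert-butyl for dimethylamino on an aromatic carbon.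

The next change leads to compound 3 `O=c1c(O)c(-c2ccc(Cl)cc2)oc2cc(O)cc(O)c12`, which has chloro in place of dimethylamino on an aromatic carbon. The site is on an aromatic carbon of a six-membered aromatic ring of carbon only, para to a large group. Among the compounds with values here, no measured compound carries chloro, so the evidence for this change is indirect and thin. Within the data shown here, the only guide is the group exchange a 1.2-fold lower number from compound 1 to compound 2 (0.06 log units; within the scatter), which stayed within the scatter. On that basis, no change beyond the scatter is expected in this assay. The expected result is a 1.0-fold lower number from compound 2 to compound 3 (0.01 log units; within the scatter). For compound 3 the estimated value is 600000 nM, with an expected range from 250000 nM to 1400000 nM.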

Compound 3, half-maximal inhibitory concentration: 27900000 nM
Compound 3: middle estimate off by 47-fold (1.67 log units), on the low side; the whole stated range lies below it.
By their numbers in this assay, from the lowest: compounds 2 and 1 (each within the scatter of the next); then compound 3.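

The site on an aromatic carbon, para to a large group, is not indifferent to its substituent in this assay: chloro in place of dimethylamino gives a 46-fold higher number from compound 2 to compound 3 (1.66 log units; beyond the scatter), and chloro in place of tert-butyl gives a 39-fold higher number from compound 1 to compound 3 (1.59 log units; beyond the scatter). The earlier tolerance therefore describes only the exchange between tert-butyl and dimethylamino, which could not be ranked, and does not extend to chloro, so compound 3 is the clear outlier among the three compounds at this site. Nothing available here accounts for the size of this shift.

From the compounds shown here alone, whether the higher number belongs to chloro as such or would also appear with other single-atom substituents remains open, and fluoro or bromo at the same site would help separate those readings. Going by these compounds, it also remains open whether a methyl, a methoxy or a plain hydrogen at this site would stay with compound 1 and compound 2 or move towards compound 3.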